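The source may report more compounds than this note shows. Statements on the series, on what has been measured and on what is new or still open speak of the compounds shown alone.

Compound 1 `OC(O)(c1c(F)c(F)c(-n2cc(-c3ccccc3)nn2)c(F)c1F)C(F)(F)F` was tested in a functional assay on HCT-116 cells (Homo sapiens) for inhibition, read by colorimetric assay, with a stated time of 3 days (a higher number here means a weaker inhibitor, a lower number a stronger inhibitor), and gives > 100000 nM, which is a limit of the assay rather than a number.
Compound 2 `O=C(CCCCCCNC(=O)C(O)(O)C(F)(F)F)Nc1ccc(Br)cc1` gives 3130 nM in this assay.
Compound 3 `CC(=O)C(=O)NCCCCCC(=O)Nc1ccccc1` gives > 100000 nM in this assay, again a limit of the assay and not a number.

Compound 2 therefore stands alone in this assay as the only result reported as a number; the two other results sit at the limit of > 100000 nM in this assay, at which 2 of the 3 values shown sit. Among the compounds with values here, no two of the measured compounds differ from each other in a single place, so no measured step is available to calibrate what a small change does here.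

Compound 4 `O=C(CCCCCCNC(=O)C(O)(O)C(F)(F)F)Nc1ccc(F)cc1` is the next compound and is not yet measured. It differs from compound 2 in one place: fluoro in place of bromo on an aromatic carbon. Within the data shown here, because compound 2 gives 3130 nM in this assay and no measured step is at hand, the expectation for this change rests on compound 2 alone, and the step from compound 2 to compound 4 in this assay is expected to be a 1.9-fold higher number from compound 2 to compound 4 (0.28 log units; within the scatter), a small move that could fall within the usual scatter, leaning if anything toward weaker inhibition. On that basis compound 4 is expected to give 6000 nM in this assay, with a range from 1500 nM to 25000 nM.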

Compound 4, half-maximal inhibitory concentration: 7570 nM
Compound 4: the middle estimate sits 1.3-fold (0.10 log units) below what was measured; measured number inside the range.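

Within the data shown here, the first single-place step is fluoro in place of bromo, which in this assay gives a 2.4-fold higher number from compound 2 to compound 4 (0.38 log units; beyond the scatter). This aromatic carbon, para to a large group, is therefore not silent: exchanging one heavy atom for another moves the reading beyond the scatter toward weaker inhibition, while compound 4 still gives a number rather than a limit of the assay. Nothing shown accounts for the size of this step.

The compounds shown leave open how chloro, methoxy or an amine would read at this same place, and whether the step would keep its size on a longer chain. Among these compounds, with only this one step, they also cannot show whether the order of fluoro and bromo holds on any other core.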